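Aryl variation on the sulfonyl sulfur: compound 4

The compounds below may be only part of what the source reports. "The series", "measured", "known", "first", "only" and "open" are said of these compounds alone.

In an assay on isolated protein for displacement of a labelled ligand from metabotropic glutamate receptor 5 (Homo sapiens), with a stated time of 60 min, tested at 1 uM (on this read-out lower numbers stand for less inhibition and higher numbers for more inhibition at the one concentration tested (going by the name of the read-out)), compound 3 `COc1ccc(S(=O)(=O)c2cnc3cc(Cl)ccc3c2N2CCC(C)CC2)cc1OC` gives 93%, the top number of the three, though the gaps to both other compounds fall within the scatter. Compound 2 `CC1CCN(c2c(S(=O)(=O)c3cccc(Cl)c3)cnc3cc(Cl)ccc23)CC1` gives 92% in this assay, and compound 1 `Cc1ccc(S(=O)(=O)c2cnc3cc(Cl)ccc3c2N2CCC(C)CC2)cc1F` gives 85%. All three share one core and differ only in the aryl group on the sulfonyl sulfur: a number 7 percentage points higher from compound 1 to compound 2 (within the scatter), a number 8 percentage points higher from compound 1 to compound 3 (within the scatter) and a number 1 percentage points higher from compound 2 to compound 3 (within the scatter), each within the scatter. Compound 4 `Cc1ccc(S(=O)(=O)c2cnc3cc(Cl)ccc3c2N2CCC(C)CC2)cc1C` continues this variation: 3,4-dimethylphenyl in place of 3,4-dimethoxyphenyl on a sulfonyl sulfur. All three measured steps bear on it, since each exchanges one aryl group for another at the same sulfonyl sulfur, and none moved the read-out beyond the scatter. The expected step is therefore a number 5 percentage points lower from compound 3 to compound 4 (within the scatter), within the scatter, with no direction claimed. Compound 4 is expected in this assay at 88%, with a range from 75% to 97%.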

Compound 4, a percentage reported as inhibition, at one concentration (the size of the read-out at that concentration, not a potency): 86%
Compound 4: middle estimate off by 2 percentage points, on the high side, within the range that was stated.
By their numbers in this assay, from the lowest: compounds 1, 4, 2 and 3 (each within the scatter of the next).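

In this assay, the exchange of 3,4-dimethoxyphenyl for 3,4-dimethylphenyl on the sulfonyl sulfur gives a number 7 percentage points lower from compound 3 to compound 4 (within the scatter), so an aryl group with 0 hydrogen-bond acceptors stays within the scatter of one with 2 hydrogen-bond acceptors. The comparison with 3-chlorophenyl gives a number 6 percentage points lower from compound 2 to compound 4 (within the scatter), and methyl in place of fluoro on an aromatic carbon gives a number 1 percentage points higher from compound 1 to compound 4 (within the scatter), which extends the flat picture to a change in a single substituent of the aryl group. No available data bear on why these aryl exchanges leave the read-out within the scatter.

Still open, as far as these compounds go, is whether a carboxylic acid or an amine on the aryl group, or a longer alkyl chain in place of the aryl group, would move the read-out beyond the scatter. A single-concentration percentage also leaves the potencies of these four compounds unresolved.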